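The compounds below may be only part of what the source reports. "The series", "measured", "known", "first", "only" and "open" are said of these compounds alone.

Compound 1 `C[C@@H]1CN(c2sc(C3CC3)nc2-c2nc3ccccc3[nH]2)CCN1C(=O)Cn1cnc2cccnc21` gives 745 nM in a functional assay on U2OS cells for antagonist activity at C-X-C chemokine receptor type 3 (Homo sapiens), read by beta-arrestin recruitment; a higher number here means a weaker inhibitor, a lower number a stronger inhibitor.
Compound 2 `C[C@@H]1CN(c2sc(CN(C)C)nc2-c2nc3ccccc3[nH]2)CCN1C(=O)Cn1cnc2cccnc21` gives 2360 nM in this assay.
Compound 3 `Cc1nc(C)n(CC(=O)N2CCN(c3sc(C(F)(F)F)nc3-c3cnc(OC4CCC4)nc3)C[C@H]2C)n1` gives 78 nM in this assay.

Of the three measured compounds, compound 3 has the lowest number; compound 1 stands nearest to it and compound 2 furthest, both gaps lying beyond the scatter. Compound 4 `CCOc1ccc(-c2nc(C(F)(F)F)sc2N2CCN(C(=O)Cn3nc(C)nc3C)[C@H](C)C2)cn1` has not yet been measured. It differs from compound 3 in one place: 6-ethoxypyridin-3-yl in place of 2-(cyclobutyloxy)pyrimidin-5-yl on an aromatic carbon. Among the compounds with values here, the only measured step, a 3.2-fold higher number from compound 1 to compound 2 (0.50 log units; beyond the scatter), concerns a different place on the shared core and a different pair of groups, so it does not bear directly on this change; it shows only that a single replacement on that core can shift the number modestly. Within the data shown here, nothing among the measured compounds tests an exchange of this aryl group itself. The step expected for compound 4 is therefore a 1.5-fold higher number from compound 3 to compound 4 (0.19 log units; within the scatter) in this assay, at most modest and possibly within the scatter. Compound 4 is estimated at 120 nM, with a range from 40 nM to 350 nM.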

Compound 4, half-maximal inhibitory concentration: 505 nM
Beside the measured number, compound 4's estimate is 4.2-fold (0.62 log units) below it; the whole stated range lies below it.
By their numbers in this assay, from the lowest: compound 3; then compounds 4 and 1 (each within the scatter of the next); then compound 2.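

Exchanging the aryl group on this aromatic carbon of the five-membered ring, next to the ring nitrogen, gives a 6.5-fold higher number from compound 3 to compound 4 (0.81 log units; beyond the scatter) in this assay. Within the data shown here, this is the first direct reading at this position, and it shows that the number responds to the aryl group there even with the rest of the molecule held constant. The exchange alters the six-membered aromatic ring and the group on its oxygen together, and nothing shown gives a measured reason for the step.

The compounds shown leave open which of those two alterations carries the step, a question that 2-ethoxypyrimidin-5-yl or 6-(cyclobutyloxy)pyridin-3-yl at this position would address. They also leave open how this position would respond to an amine or a carboxylic acid in place of the ether.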